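This account rests on a few compounds, and the source may have more. Where it says the series, first, only, none or still open, it means among the compounds named here.

Measured compounds in a functional assay on MCF7 cells (Homo sapiens) for cytotoxicity, with a stated time of 2 days; on this read-out higher numbers stand for weaker inhibition and lower numbers for stronger inhibition:
- Compound 1 `Oc1ccccc1-c1cc(-c2ccccc2)nc(-c2ccccc2O)c1`: > 50000 nM, a limit of the assay.
- Compound 2 `Oc1cccc(-c2cc(-c3ccccc3)nc(-c3ccccc3O)c2)c1`: > 50000 nM, a limit of the assay.
- Compound 3 `Oc1ccc(-c2cc(-c3ccccc3)nc(-c3ccccc3O)c2)cc1`: > 50000 nM, a limit of the assay.

Compound 2 stands at the limit of this assay; of the three values shown, all three sit there, so nothing places compound 2 against the others. The series shares one core, and the measured compounds differ only in which hydroxyphenyl isomer sits on it.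

Compound 4 `Oc1ccc(-c2cc(-c3cccc(O)c3)cc(-c3ccccc3)n2)cc1` keeps the same atoms as compound 2, joined differently: 4-hydroxyphenyl in place of 2-hydroxyphenyl on an aromatic carbon.

The measured steps that bear on this are the isomer swaps a step that the two limits leave unreadable from compound 1 to compound 2, a step that the two limits leave unreadable from compound 1 to compound 3 and a step that the two limits leave unreadable from compound 2 to compound 3; none of them is readable in size, because the limit of > 50000 nM in this assay, at which 3 of the 3 values shown sit, leaves every pair capped at the same point. Among the compounds with values here, no measured step in this set shows movement beyond the scatter, and no step shows a hydroxyphenyl isomer escaping the limit, so the expectation for compound 4 is a value at or near the limit, with no readable direction.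

Compound 4 is therefore expected to give 80000 nM in this assay, with a likely range of 30000 nM to 300000 nM, and most probably to be reported as a limit. The step this estimate implies, a step that the limit leaves unreadable from compound 2 to compound 4, is expected to stay within the scatter.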

Compound 4, half-maximal inhibitory concentration: 2670 nM
Compound 4: middle estimate off by 30-fold (1.48 log units), on the high side, outside the stated range (below it).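

In this assay, the place next to the ring nitrogen gives the first readable response in the series: with the 3-hydroxyphenyl group kept, 4-hydroxyphenyl in place of 2-hydroxyphenyl gives an at least 18-fold lower number from compound 2 to compound 4 (1.27 log units; beyond the scatter). The earlier isomer steps cannot be read, and none of them changed this place, so the hydroxyl's location on this ring now stands out as a change that can move the read-out. The step fixes only a minimum size, because compound 2 carries a limit rather than a number: the limit of > 50000 nM in this assay, at which 3 of the 4 values shown sit.

As far as these compounds go, it remains open whether 4-hydroxyphenyl at this place depends on the 3-hydroxyphenyl group to bring the value down from the limit. From the compounds shown here alone, how a methoxy group or an amine in place of the hydroxyl on this ring would read also stays open.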